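Thiophene Isomers on a Nucleoside Core in a Cell Assay

The source may report more compounds than this note shows. Statements on the series, on what has been measured and on what is new or still open speak of the compounds shown alone.

Measured compounds:
Compound 1, `O=c1[nH]cnc2c1c(-c1cccs1)cn2[C@@H]1O[C@H](CO)[C@@H](O)[C@H]1O`, in a functional assay on A549 cells (Homo sapiens), read by MTT assay, with a stated time of 72 h (a lower number here means a stronger inhibitor, a higher number a weaker inhibitor), gives only a limit: > 20000 nM.
Compound 2, `O=c1[nH]cnc2c1c(-c1ccsc1)cn2[C@@H]1O[C@H](CO)[C@@H](O)[C@H]1O`, in this assay gives only a limit: > 20000 nM.
Compound 3, `CNc1ncnc2c1c(-c1cccs1)cn2[C@@H]1O[C@H](CO)[C@@H](O)[C@H]1O`, in this assay gives only a limit: > 20000 nM.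

All three measured compounds sit at the limit of > 20000 nM in this assay, at which 3 of the 3 values shown sit, so none of them has a readable number in this assay. Compound 1 and compound 2 differ by thiophen-3-yl in place of thiophen-2-yl on an aromatic carbon, and the step that the two limits leave unreadable from compound 1 to compound 2 cannot be sized, since both ends are limits. Compound 3 differs from compound 1 in more than one place, and the difference between the two cores is not broken down here.

Compound 4, `CNc1ncnc2c1c(-c1ccsc1)cn2[C@@H]1O[C@H](CO)[C@@H](O)[C@H]1O`, has not yet been measured. For the measured compounds named here, it differs from compound 3 by thiophen-3-yl in place of thiophen-2-yl on an aromatic carbon, which is the same change as the one from compound 1 to compound 2, made at the same place on the core. Since that earlier change left compound 2 at the same limit as compound 1, the expectation is that the step that the limit leaves unreadable from compound 3 to compound 4 will likewise be too small to lift compound 4 out of the limit region. Compound 4 is therefore expected to sit around 40000 nM in this assay, with a range from 15000 nM to 200000 nM, and most probably to be reported again only as a limit.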

Compound 4, half-maximal inhibitory concentration: > 20000 nM
Compound 4 was reported as a limit; the forecaster's own chance of this, stated with the estimate: 85%; the middle value does not contradict the limit.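

In this assay compound 4 gives > 20000 nM as a limit and not a number. No step can be read from compound 3 to compound 4, as both ends are limits: the limit of > 20000 nM in this assay, at which 4 of the 4 values shown sit.

The compounds shown leave open how strongly any of the four inhibits in this assay and whether thiophen-3-yl and thiophen-2-yl differ at all on either core.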